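Changing the acyl aryl group of compound 2

This account rests on a few compounds, and the source may have more. Where it says the series, first, only, none or still open, it means among the compounds named here.

Compounds measured so far:
- compound 1, `CN(C(=O)NC(=O)c1cccc(C(F)(F)F)c1)c1nc(C(F)(F)F)c(C(=O)N/N=C/c2cccc(C(F)(F)F)c2)s1`: 3.7 ug/mL
- compound 2, `CN(C(=O)NC(=O)c1cccc(C(F)(F)F)c1)c1nc(C(F)(F)F)c(C(=O)N/N=C/c2ccccc2C(F)(F)F)s1`: 7.69 ug/mL
- compound 3, `CN(C(=O)NC(=O)c1cccc(C(F)(F)F)c1)c1nc(C(F)(F)F)c(C(=O)N/N=C/c2ccc(C(F)(F)F)cc2)s1`: 6.5 ug/mL

In a functional assay on MCF7 cells (Homo sapiens) for inhibition, read by MTT assay, with a stated time of 72 h (a higher number here means a weaker inhibitor, a lower number a stronger inhibitor), compound 2 gives the highest number of the three: to compound 3 the gap is within the scatter, while a 2.1-fold higher number from compound 1 to compound 2 (0.32 log units; beyond the scatter) lies beyond it. Compound 4, `CN(C(=O)NC(=O)c1ccc(Cl)cc1Cl)c1nc(C(F)(F)F)c(C(=O)N/N=C/c2ccccc2C(F)(F)F)s1`, differs from compound 2 at the other end of the shared core: 2,4-dichlorophenyl in place of 3-(trifluoromethyl)phenyl on a carbonyl carbon. The measured steps all alter the group on the carbon with a double bond to nitrogen, so none bears on this change, and they gave only modest or within-scatter moves. Without a comparable step, no move beyond the scatter is expected for compound 4 in this assay, so the estimate is a 1.0-fold lower number from compound 2 to compound 4 (0.01 log units; within the scatter), giving 7.5 ug/mL (range 3 ug/mL to 18 ug/mL).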

Compound 4, half-maximal inhibitory concentration: 9.12 ug/mL
Compound 4: the middle estimate sits 1.2-fold (0.08 log units) below what was measured; the range from low to high includes it.
By their numbers in this assay, from the lowest: compounds 1, 3, 2 and 4 (each within the scatter of the next, the first and the last beyond it).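

Within the data shown here, this is the first look at the aryl group on the carbonyl carbon: in this assay, 2,4-dichlorophenyl in place of 3-(trifluoromethyl)phenyl gives a 1.2-fold higher number from compound 2 to compound 4 (0.07 log units; within the scatter). With the rest of compound 2 held fixed, exchanging one substituted phenyl for the other therefore shows no real difference. No measurement at hand bears on the reason for this result.

Going by these compounds, whether this position accepts a pyridine ring, a cyclohexyl ring or a short alkyl chain stays open. So does whether 2,4-dichlorophenyl gives the same result on compound 1.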